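Working notes: 4-bromophenyl in place of 3-hydroxyphenyl

A few compounds are considered here, and "the series" means these few. Any claim that something is new, unique, unknown or untested is made for them only; others in the source may bear on it.

In a physicochemical assay for lipophilicity, measured as octanol-water partition (on this read-out higher numbers stand for higher lipophilicity and lower numbers for lower lipophilicity), compound 1 (`CC1=C(C(=O)OCc2cccnc2)C(c2ccc(C#N)cc2)C2=C(CCCC2=O)N1`) gives 1.36 and compound 2 (`CC1=C(C(=O)OCc2cccnc2)C(c2cccc(O)c2)C2=C(CCCC2=O)N1`) gives 1.21. Going by the values given here, compound 2 therefore stands level with compound 1 within the scatter, and the series holds no other number so far. The next structure is compound 3 (`CC1=C(C(=O)OCc2cccnc2)C(c2ccc(Br)cc2)C2=C(CCCC2=O)N1`), which keeps the shared core and carries 4-bromophenyl in place of 3-hydroxyphenyl on a saturated ring carbon. Among the compounds with values here, one measured step bears on this change, a number 0.15 log units lower from compound 1 to compound 2 (within the scatter), an exchange of aryl groups on the same saturated ring carbon. Within the data shown here, that step is small, but it is a weak guide, since no measured compound carries bromine. Among the measured compounds shown here, the hydrogen-bond donor and acceptor of the leaving group have no counterpart in the entering group. For the measured compounds named here, on that structural difference, a rise beyond the scatter in this assay is expected, although no measured step fixes its size, so the range stays wide. The expected change is a number 0.99 log units higher from compound 2 to compound 3 (beyond the scatter). For compound 3 the estimated value is 2.2, with an expected range from 1.6 to 2.9.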

Compound 3, partition coefficient: 2.05
Beside the measured number, compound 3's estimate is 0.15 log units above it; low and high end bracket the measured number.
By their numbers in this assay, from the lowest: compounds 2 and 1 (each within the scatter of the next); then compound 3.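

In this assay, the aryl group on this saturated ring carbon now gives a step beyond the scatter (a number 0.84 log units higher from compound 2 to compound 3 (beyond the scatter)) with 4-bromophenyl in place of 3-hydroxyphenyl, whereas the earlier exchange of aryl groups on the same carbon stayed within it. The second step (a number 0.69 log units higher from compound 1 to compound 3 (beyond the scatter)) is bromo in place of cyano on an aromatic carbon, which shows that this single exchange on the aromatic ring, with the shared core unchanged, also moves the read-out beyond the scatter. No measurement on hand accounts for either step.

The 3-hydroxyphenyl and 4-bromophenyl groups differ both in the substituent and in where it stands on the aromatic ring, so the compounds shown cannot separate these two changes. Also open, on these data alone, is where a plain phenyl, a 4-chlorophenyl or an aminophenyl group on this carbon would fall relative to these numbers, and whether the bromo step would hold at another place on the aromatic ring.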